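The compounds below may be only part of what the source reports. "The series", "measured", "known", "first", "only" and "open" are said of these compounds alone.

Compound 1 `CC1CC/C(=N\Nc2ccccc2C(F)(F)F)c2ncc(C(=O)O)c(=O)n21`: in a functional assay on the whole organism for inhibition, with Rattus norvegicus as the target (a lower number here means that less compound is needed, a higher number that more compound is needed for the effect), compound 1 gives > 1000 umol/kg, which is a limit of the assay.
Compound 2 `CC1CC/C(=N\Nc2cccc(C(F)(F)F)c2)c2ncc(C(=O)O)c(=O)n21`: in this assay compound 2 gives > 1000 umol/kg, likewise a limit.
Compound 3 `CC(=O)c1ccccc1N/N=C1\CCC(C)n2c1ncc(C(=O)O)c2=O`: in this assay compound 3 gives > 1000 umol/kg, again a limit.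

Compound 1 and compound 2 have the same atoms joined differently; the difference between the two cores is not broken down here. Compound 3 arises from compound 1 by acetyl in place of trifluoromethyl on an aromatic carbon. The step is a step that the two limits leave unreadable from compound 1 to compound 3 since both values sit at the limit of > 1000 umol/kg in this assay, at which 3 of the 3 values shown sit. Compound 4 `CC(=O)c1cccc(N/N=C2\CCC(C)n3c2ncc(C(=O)O)c3=O)c1` arises from compound 2 by acetyl in place of trifluoromethyl on an aromatic carbon. This is the same kind of change as that from compound 1 to compound 3, though the place differs: ortho to a large group in compound 3, meta to a large group in compound 4. An expected step that the limit leaves unreadable from compound 2 to compound 4 in this assay rests on the three measured values all sitting at the limit of > 1000 umol/kg in this assay, at which 3 of the 3 values shown sit. Compound 4 is therefore estimated at 1500 umol/kg, with a range from 300 umol/kg to 6000 umol/kg.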

Compound 4, dose for 50% inhibition: > 1000 umol/kg
Compound 4: no number, only a limit; the forecaster's own chance of this, stated with the estimate: 85%; the middle value lies beyond the limit too.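

No step can be read from compound 2 to compound 4, since both values are limits: the limit of > 1000 umol/kg in this assay, at which 4 of the 4 values shown sit.

The compounds shown leave open what dose of any of them gives the effect in this assay, and how acetyl and trifluoromethyl compare there.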